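One Inverted Stereocentre in a Compound at the Assay Limit

The source may report more compounds than this note shows. Statements on the series, on what has been measured and on what is new or still open speak of the compounds shown alone.

Compound 1 `CCOC(=O)[C@]1(C(=O)Nc2ccccc2)C[C@H]1c1cc(OC)c(OC)c(OC)c1` gives > 100000 nM
Compound 2 `CCOC(=O)[C@@]1(C(=O)NCc2ccc(C)cc2)C[C@H]1c1cc(OC)c(OC)c(OC)c1` gives > 100000 nM

In a functional assay on SW480 cells (Homo sapiens) for cytotoxicity, read by MTT assay, with a stated time of 48 h (a higher number here means a weaker inhibitor, a lower number a stronger inhibitor), compound 2 gives > 100000 nM as a limit of the assay, not a number. Compound 1 gives > 100000 nM as a limit too. Compound 3 `CCOC(=O)[C@]1(C(=O)NCc2ccc(C)cc2)C[C@H]1c1cc(OC)c(OC)c(OC)c1` differs from compound 2 in one way only (the two compounds have the same atoms and bonds and differ only in configuration as drawn: 1 of 2 stereo elements differ; a stereocentre at a saturated ring carbon is drawn S in compound 2 and R in compound 3). Within the data shown here, no measured step shows what such a change does, and the data so far show only the limit of > 100000 nM in this assay, at which 2 of the 2 values shown sit, for both compounds. The expected step of a number no higher from compound 2 to compound 3 (the limit leaves the size open) stays within the usual scatter, with no direction favoured. For compound 3 the estimate is 100000 nM (expected range 35000 nM to 100000 nM), probably again reported as a limit.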

Compound 3, half-maximal inhibitory concentration: 36400 nM
Estimate against measurement, compound 3: 2.7-fold (0.44 log units) above, within the range that was stated.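

In this assay, an at least 2.7-fold lower number from compound 2 to compound 3 (0.43 log units; beyond the scatter) shows that the stereocentre at this saturated ring carbon matters, and the change can be assigned to that centre alone, drawn S and then R, because of this: the fact that compounds 2 and 3 differ only in the configuration as drawn The group on the amide-type nitrogen matters too, as 4-methylbenzyl in place of phenyl gives an at least 2.7-fold lower number from compound 1 to compound 3 (0.43 log units; beyond the scatter). Both steps are minimum sizes because each starts from a compound at a limit: the limit of > 100000 nM in this assay, at which 2 of the 3 values shown sit.

On these data alone, whether a longer chain or a carboxylic acid on the amide-type nitrogen would lower the number further remains open. As far as these compounds go, the true size of both steps also remains open.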